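The compounds below may be only part of what the source reports. "The series", "measured", "known", "first", "only" and "open" are said of these compounds alone.

Measured in an ADME assay on HEK-293T cells (Homo sapiens) for cytotoxicity, read by CCK-8 assay, with a stated time of 48 h; on this read-out higher numbers stand for lower toxicity in this test and lower numbers for higher toxicity in this test:
Compound 1 `O=C(CNc1nc(N2CCc3ccccc3C2)nc2ccccc12)Nc1ccc2ccccc2c1`: > 100000 nM (a limit of the assay)
Compound 2 `O=C(CNc1nc(N2CCCC2)nc2ccccc12)Nc1ccc2ccccc2c1`: 59900 nM
Compound 3 `O=C(CSc1nc(N2CCCC2)nc2ccccc12)NCc1ccc2ccccc2c1`: > 100000 nM (a limit of the assay)

Compound 2 is the only one of these with an actual number, as the other two values are limits. Compound 4 `O=C(CNc1nc(N2CCCC2)nc2ccccc12)NCc1ccco1` differs from compound 2 in one place: (furan-2-yl)methyl in place of naphthalen-2-yl on an amide-type nitrogen. In short, (furan-2-yl)methyl stands in place of naphthalen-2-yl on an amide-type nitrogen. Among the measured compounds shown here, no measured step changes that nitrogen. For the measured compounds named here, the single step available, an at least 1.6-fold lower number from compound 1 to compound 2 (0.22 log units; that floor lies within the scatter), lies on an aromatic carbon instead, so it is only a weak guide. Also worth noting is the limit of > 100000 nM in this assay, at which 2 of the 3 values shown sit. No change beyond the usual scatter is therefore expected, and the expected step is a 1.4-fold higher number from compound 2 to compound 4 (0.15 log units; within the scatter). For compound 4 the estimate is 85000 nM, with an expected range from 40000 nM to 180000 nM.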

Compound 4, half-maximal cytotoxic concentration: > 100000 nM
Compound 4: no number, only a limit; the forecaster's own chance of this, stated with the estimate: 55%; middle value at least 1.1-fold (0.07 log units) away from the limit.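

In this assay, putting (furan-2-yl)methyl in place of naphthalen-2-yl on the amide-type nitrogen gives an at least 1.6-fold higher number from compound 2 to compound 4 (0.22 log units; that floor lies within the scatter). Compound 4 reads > 100000 nM, which is a limit of the assay and not a number. This change at that nitrogen brings no sign of higher toxicity in this test, but its true size cannot be read, and only a floor is known: the limit of > 100000 nM in this assay, at which 3 of the 4 values shown sit.

As far as these compounds go, how far compound 4 really lies from compound 2 stays open. So does whether a benzyl group, or a longer chain ending in an amine, on that nitrogen would lower the number.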